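Swapping Bromo for Chloro a Second Time

The source may report more compounds than this note shows. Statements on the series, on what has been measured and on what is new or still open speak of the compounds shown alone.

The measured compounds, tested in an ADME assay on MCF-10A cells (Homo sapiens) for cytotoxicity, read by sulforhodamine B assay, with a stated time of 48 h; on this read-out lower numbers stand for stronger inhibition of growth and higher numbers for weaker inhibition of growth:
compound 1, `O=C1C(=O)N(CN2CCN(c3ccnc4cc(Cl)ccc34)CC2)c2cc(Cl)ccc21`, gives 67800 nM.
compound 2, `O=C1C(=O)N(CN2CCN(c3ccnc4cc(Cl)ccc34)CC2)c2cc(Br)ccc21`, gives 18000 nM.
compound 3, `O=C1C(=O)N(CN2CCN(c3ccnc4cc(C(F)(F)F)ccc34)CC2)c2cccc(Cl)c21`, gives 24000 nM.

Compounds 1 and 2 share a core and differ in one place, (bromo in place of chloro on an aromatic carbon). This change gave a 3.8-fold lower number from compound 1 to compound 2 (0.58 log units; beyond the scatter) in this assay, a step that is modest but clear.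

Compound 3 carries a different core, and the difference between the two cores is not broken down here. Compound 4, `O=C1C(=O)N(CN2CCN(c3ccnc4cc(C(F)(F)F)ccc34)CC2)c2cccc(Br)c21`, has not yet been measured. It differs from compound 3 by bromo in place of chloro on an aromatic carbon. The two halogen swaps are the same kind of change, but not the same: in the first, the halogen sits meta to a fused ring and para to a fused ring, while in the second it sits ortho to a fused ring and meta to a fused ring.

Because the earlier swap produced a 3.8-fold lower number from compound 1 to compound 2 (0.58 log units; beyond the scatter), a step in the same direction is expected from compound 3 to compound 4 in this assay. Since the surroundings of the place differ, the expected step is taken as somewhat smaller, a 2.4-fold lower number from compound 3 to compound 4 (0.38 log units; beyond the scatter). Compound 4 is therefore estimated at 10000 nM, with a likely range from 4000 nM to 24000 nM.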

Compound 4, concentration for 50% growth inhibition: 37900 nM
Estimate against measurement, compound 4: 3.8-fold (0.58 log units) below; measured number above the stated range.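

In this assay, putting bromo in place of chloro on the core of compound 3 gives a 1.6-fold higher number from compound 3 to compound 4 (0.20 log units; within the scatter), so this pair shows no change that can be told apart from the ordinary spread of repeated measurements. The clear step seen on the core of compound 1 therefore did not carry over to the core of compound 3, and the two results really do differ: the same change on two cores in this assay, a 3.8-fold lower number (0.58 log units; beyond the scatter) from compound 1 to compound 2 and a 1.6-fold higher number (0.20 log units; within the scatter) from compound 3 to compound 4, 5.9-fold (0.77 log units) apart, beyond the scatter of two such steps. This shows that the same halogen swap cannot be assumed to act alike on both cores, but it does not show why, since the halogen's place and the rest of the molecule both change between the two pairs, and two pairs alone give no general rule.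

The compounds shown leave open whether the swap would repeat its clear step if the halogen stood at its place in compound 2 on a core carrying trifluoromethyl, which would separate the effect of place from that of the rest of the core. They also leave open how a fluoro, a methoxy or an amine would read at the place now held by chloro or bromo in compound 3 and compound 4.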